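The source may report more compounds than this note shows. Statements on the series, on what has been measured and on what is new or still open speak of the compounds shown alone.

Measured so far:
compound 1 `CCCCNc1nnc(SCC(=O)N(Cc2cccc([N+](=O)[O-])c2)c2ccc(F)cc2)s1`: 30%
compound 2 `CC(C)CNc1nnc(SCC(=O)N(Cc2cccc([N+](=O)[O-])c2)c2ccc(F)cc2)s1`: 25.5%

In an assay on isolated protein for inhibition of Amine oxidase [flavin-containing] A (Homo sapiens), read by fluorescence and Amplex Red, with a stated time of 30 min, tested at 0.01 uM (a lower number here means a weaker effect, a higher number a stronger effect of the compound at the concentration tested), compound 2 stands at the smaller of the two numbers, with compound 1 within the scatter of it. Going by the values given here, the one measured step, a number 4.5 percentage points lower from compound 1 to compound 2 (within the scatter), altered the chain on the same nitrogen and stayed within the scatter. Compound 3 `CC(C)Nc1nnc(SCC(=O)N(Cc2cccc([N+](=O)[O-])c2)c2ccc(F)cc2)s1` differs from compound 2 by isopropyl in place of isobutyl on a nitrogen on an aromatic ring. That step bears directly on this change and was small, so no movement beyond the scatter is expected; the expected step is a number 1.5 percentage points higher from compound 2 to compound 3 (within the scatter). Compound 3 is therefore estimated at 27%, within 15% to 39%.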

Compound 3, a percentage reported as inhibition, at one concentration (the size of the read-out at that concentration, not a potency): 23.9%
Compound 3: middle estimate off by 3.1 percentage points, on the high side, and the stated range covers the measured number.
By their numbers in this assay, from the lowest: compounds 3, 2 and 1 (each within the scatter of the next).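

In this assay isopropyl in place of isobutyl on a nitrogen on an aromatic ring reads a number 1.6 percentage points lower from compound 2 to compound 3 (within the scatter) and isopropyl in place of butyl reads a number 6.1 percentage points lower from compound 1 to compound 3 (within the scatter) on the same nitrogen. Butyl, isobutyl and isopropyl at this position are therefore not told apart at the tested concentration, and this now holds for the chain of 3 carbons as well. No measured information bears on these results. On these data alone, whether a cyclohexyl ring, a benzyl group or a chain ending in a carboxylic acid on this nitrogen would move the read-out beyond the scatter stays open.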